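Swapping an isobutylpyrazolyl for an imidazolyl: cytotoxicity outlook

The source may report more compounds than this note shows. Statements on the series, on what has been measured and on what is new or still open speak of the compounds shown alone.

Of the compounds shown here, two of this set have so far been tested in an ADME assay on BaF3 cells (Mus musculus) for cytotoxicity; a higher number here means that more compound is needed for the effect, a lower number that less compound is needed. Compound 1 `NC(=O)c1cccc(Oc2cc(Nc3ccc(OC(F)(F)F)cc3)ncn2)c1` reports only a limit there: in this assay compound 1 gives > 10000 nM. Compound 2 `CC(C)Cn1cc(-c2cc(Nc3ccc(OC(F)(F)F)cc3)ncn2)cn1` likewise reaches only a limit, as in this assay compound 2 gives > 10000 nM. Within the data shown here, both measured values thus sit at the limit of > 10000 nM in this assay, at which 2 of the 2 values shown sit, so compound 2 stands at the same limit as the only other measured compound, and no step between measured compounds can be drawn from these numbers.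

Compound 3 `FC(F)(F)Oc1ccc(Nc2cc(-n3ccnc3)ncn2)cc1` differs from compound 2 in a single position: 1H-imidazol-1-yl in place of 1-isobutyl-1H-pyrazol-4-yl on an aromatic carbon. Among the measured compounds shown here, since both values measured so far are limits, nothing in the data shows how a change of this kind shifts the number. Given that compound 2 and compound 1 both sit at the limit of > 10000 nM in this assay, at which 2 of the 2 values shown sit, compound 3 is expected to reach only the limit as well. The step that the limit leaves unreadable from compound 2 to compound 3 is therefore expected to amount to nothing beyond the scatter. Compound 3 is accordingly estimated at 15000 nM, within a range from 5000 nM to 50000 nM.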

Compound 3, half-maximal effective concentration: > 10000 nM
Compound 3: a limit, no number; the forecaster's own chance of this, stated with the estimate: 85%; the middle value lies beyond the limit too.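

In this assay compound 3 gives > 10000 nM, a limit and not a number. Among these compounds, compound 2 also reaches only a limit, so no step from compound 2 to compound 3 can be read. The compounds shown leave open how 1H-imidazol-1-yl in place of 1-isobutyl-1H-pyrazol-4-yl shifts cytotoxicity, since all of them stand at one limit: the limit of > 10000 nM in this assay, at which 3 of the 3 values shown sit.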